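Swapping thiophen-3-yl for cyclopentyl on a thiophene-bearing core

The source may report more compounds than this note shows. Statements on the series, on what has been measured and on what is new or still open speak of the compounds shown alone.

Three compounds share one core and differ only in the group attached to the thiophene ring. Compound 1 `C[C@H]1[C@H](NCc2cc(C3CC3)cs2)C[C@H]2C[C@@H]1C2(C)C` carries a cyclopropyl there, compound 2 `C[C@H]1[C@H](NCc2cccs2)C[C@H]2C[C@@H]1C2(C)C` a hydrogen and compound 3 `C[C@H]1[C@H](NCc2cc(-c3ccsc3)cs2)C[C@H]2C[C@@H]1C2(C)C` a thiophen-3-yl. In an ADME assay on MDCK cells (Canis lupus familiaris) for cytotoxicity, read by microscopy, with a stated time of 48 h (on this read-out lower numbers stand for higher toxicity in this test and higher numbers for lower toxicity in this test), compound 1 gives 25000 nM, compound 2 gives 25000 nM and compound 3 gives 25000 nM. The steps of no change at the digits printed from compound 1 to compound 2 (within the scatter), no change at the digits printed from compound 1 to compound 3 (within the scatter) and no change at the digits printed from compound 2 to compound 3 (within the scatter) show that none of these groups moves the read-out. Compound 4 `C[C@H]1[C@H](NCc2cc(C3CCCC3)cs2)C[C@H]2C[C@@H]1C2(C)C` differs from compound 3 by cyclopentyl in place of thiophen-3-yl on an aromatic carbon. All three measured steps stayed flat, and the step to compound 4 is expected to stay flat as well, no change at the digits printed from compound 3 to compound 4 (within the scatter). Compound 4 is therefore estimated at 25000 nM, between 12500 nM and 50000 nM.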

Compound 4, minimum cytotoxic concentration: 1560 nM
The estimate for compound 4 lay 16-fold (1.20 log units) above the measured number, and the stated range ends above it.
By their numbers in this assay, from the lowest: compound 4; then compounds 1, 2 and 3 (each within the scatter of the next).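

In this assay this position proves able to change the read-out: cyclopentyl gives a 16-fold lower number from compound 3 to compound 4 (1.20 log units; beyond the scatter) and also a 16-fold lower number from compound 2 to compound 4 (1.20 log units; beyond the scatter) and a 16-fold lower number from compound 1 to compound 4 (1.20 log units; beyond the scatter) on the same aromatic carbon. Thiophen-3-yl and cyclopentyl each hold 5 heavy atoms, so this count alone does not separate them, although one ring is aromatic with a sulfur and the other is non-aromatic and all carbon. No available evidence explains the drop. On these data alone, it remains open whether cyclobutyl or cyclohexyl would lower the number as cyclopentyl does, and what a cyclopentyl ring carrying an amine would do.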